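Flavanone Analogues Tested on Mouse Lymphoma Cells

A few compounds are considered here, and "the series" means these few. Any claim that something is new, unique, unknown or untested is made for them only; others in the source may bear on it.

Measured compounds:
compound 1, `COc1cc(O)c2c(c1)O[C@H](c1ccc(O)cc1)C/C2=N\NC(=O)Cc1c[nH]c2ccccc12`: >= 11300 nM
compound 2, `COc1ccc([C@@H]2CC(=O)c3c(O)cc(OC)cc3O2)cc1`: >= 11300 nM
compound 3, `COc1ccc([C@@H]2C/C(=N\N)c3c(O)cc(OC)cc3O2)cc1`: >= 11300 nM

The assay is a functional assay on L5178Y cells (Mus musculus) for inhibition, read by MTT assay, with a stated time of 24 h; a lower number here means a stronger inhibitor, a higher number a weaker inhibitor. In this assay compound 1 reaches only a limit, >= 11300 nM. Compound 2, the parent of the step followed here, likewise reaches only a limit in this assay, >= 11300 nM. Compound 3 also gives no number in this assay but a limit, >= 11300 nM. Compound 2 therefore stands nowhere distinct among the three: all sit at the limit of >= 11300 nM in this assay, at which 3 of the 3 values shown sit, and no order among them can be read.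

The unmeasured compound 4, `COc1cc(O)c2c(c1)O[C@H](c1ccc(OCC(O)CSc3ccccc3)cc1)CC2=O`, differs from compound 2 in one place: 1-hydroxy-2-(phenylsulfanyl)ethyl in place of hydrogen on a saturated chain carbon bound to an oxygen on an aromatic ring. For the measured compounds named here, no measured pair in this set changes in one place, so no step size can be borrowed; the three values only show that the shared core, with these substituents, does not reach a measurable inhibitory concentration here.

On that basis compound 4 is expected to remain in the same region, with a step that the limit leaves unreadable from compound 2 to compound 4 that is expected to be none beyond the usual scatter. The estimate for compound 4 is 15000 nM, expected between 5000 nM and 50000 nM, most likely again reported only as a limit.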

Compound 4, half-maximal inhibitory concentration: >= 11300 nM
Compound 4 gave a limit, no number; the forecaster's own chance of this, stated with the estimate: 75%; the middle value lies beyond the limit too.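

Compound 4 gives >= 11300 nM, a limit and not a number. No step from compound 2 to compound 4 can be read, because both stand at the same limit: the limit of >= 11300 nM in this assay, at which 4 of the 4 values shown sit.

The compounds shown leave open how strongly any of them inhibits, and whether 1-hydroxy-2-(phenylsulfanyl)ethyl in place of hydrogen changes inhibition at all.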